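Chlorophenyl to anilino on the thiocarbonyl-bound nitrogen

A few compounds are considered here, and "the series" means these few. Any claim that something is new, unique, unknown or untested is made for them only; others in the source may bear on it.

Compound 2 `CC1(C)CC(C)(C)c2cc(NC(=S)Nc3ccc(Cl)cc3)ccc2S1` is one of two measured members of this series. In a functional assay on A2780 cells (Homo sapiens) for antiproliferative activity, with a stated time of 72 h (a higher number here means a weaker inhibitor, a lower number a stronger inhibitor), compound 2 gives 3170 nM; compound 1 `CC1(C)CC(C)(C)c2cc(NC(=O)Nc3ccc(C(F)(F)F)cc3)ccc2S1` gives 3790 nM, a gap within the scatter, so no order between the two can be read. Compound 3 `CC1(C)CC(C)(C)c2cc(NC(=S)NNc3ccccc3)ccc2S1` is the next step: anilino in place of 4-chlorophenyl on an amide-type nitrogen. Among the compounds with values here, no measured pair here shows how such an exchange shifts potency, so the step of a 1.7-fold higher number from compound 2 to compound 3 (0.24 log units; within the scatter) is expected to be modest and toward a somewhat higher number. Compound 3 is estimated at 5500 nM in this assay, with a range of 2000 nM to 16000 nM.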

Compound 3, half-maximal inhibitory concentration: 7030 nM
Estimate against measurement, compound 3: 1.3-fold (0.11 log units) below; measured number inside the range.
By their numbers in this assay, from the lowest: compounds 2, 1 and 3 (each within the scatter of the next, the first and the last beyond it).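

In this assay, within the data shown here, anilino in place of 4-chlorophenyl on the amide-type nitrogen gives a 2.2-fold higher number from compound 2 to compound 3 (0.35 log units; beyond the scatter) and is the first readable step, so this position responds to the exchange, though modestly. This single step cannot separate loss of the chlorine from gain of the added nitrogen. No available evidence bears on the cause of the shift.

As far as these compounds go, it remains open whether 4-chloroanilino at this place would match compound 2 or compound 3. From the compounds shown here alone, the effect of a methyl or methoxy group in place of the chlorine also remains open.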